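A few compounds are considered here, and "the series" means these few. Any claim that something is new, unique, unknown or untested is made for them only; others in the source may bear on it.

- in an ADME assay on cells (Macrophage) for cytotoxicity, read by resazurin assay, with a stated time of 48 h (on this read-out lower numbers stand for higher toxicity in this test and higher numbers for lower toxicity in this test), compound 1 `O=C(/C=C/c1ccccc1)c1ccc(OCc2cn(Cc3ccc(Br)cc3)nn2)cc1O` gives 71700 nM
- compound 2 `COc1ccc(-c2cc(-c3ccc(OCc4cn(Cc5ccccc5)nn4)cc3O)nc(N)n2)cc1` gives 42700 nM as its reading
- compound 3 `CCCCCCn1cc(COc2ccc(-c3cc(-c4ccc(OC)cc4)nc(N)n3)c(O)c2)nn1` is recorded as "not determined" (no result reported)

For the measured compounds named here, only two numbers are available so far. Compound 2 at 42700 nM and compound 1 at 71700 nM lie within the usual scatter of each other, so neither can be placed ahead of the other. Compound 3 adds nothing to this comparison.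

The next compound to be read in this assay is compound 4 `CC(C)c1ccc(-c2cc(-c3ccc(OCc4cn(Cc5ccccc5)nn4)cc3O)nc(N)n2)cc1`, which departs from compound 2 in one place: isopropyl in place of methoxy on an aromatic carbon, para to a large group. The same difference can be read as 4-methoxyphenyl to 4-isopropylphenyl.

Going by the values given here, no two measured compounds differ in one place only, so the series offers no direct precedent for this exchange. The estimate therefore stays close to the reading of compound 2 at 42700 nM and keeps a wide range. A slight move toward lower numbers is expected, but nothing beyond the scatter. The expected change is a 1.3-fold lower number from compound 2 to compound 4 (0.13 log units; within the scatter) in this estimate. For compound 4 the estimated value is 32000 nM, with an expected range from 13000 nM to 75000 nM as the working bounds.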

Compound 4, half-maximal cytotoxic concentration: > 100000 nM
Compound 4 gave a limit, no number; the forecaster's own chance of this, stated with the estimate: 15%; middle value at least 3.1-fold (0.49 log units) away from the limit.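

In this assay compound 4 reads > 100000 nM, which is a limit of the assay and not a number. For the compounds shown here, the exchange of methoxy for isopropyl on an aromatic carbon, para to a large group, gives an at least 2.3-fold higher number from compound 2 to compound 4 (0.36 log units; beyond the scatter), which is the first step between compounds differing in one place and shows that the read-out responds to this position on the shared core. Only the lower end of this step is fixed, and its full size cannot be read, as compound 4 stands at the limit of the test: the limit of > 100000 nM in this assay, at which 1 of the 4 values shown sits.

With one exchange shown at this place, the data do not separate the effect of isopropyl entering from that of methoxy, with its hydrogen-bond acceptor, leaving. On these data alone, what an amine or a carboxylic acid would read at the same place stays open, as does whether the same exchange would give a comparable step on the core of compound 1.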